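Adding ethoxy to the side chain of compound 2

A few compounds are considered here, and "the series" means these few. Any claim that something is new, unique, unknown or untested is made for them only; others in the source may bear on it.

Compound 1 `Cc1noc(CC2OC(=O)c3ccccc32)n1`: > 40000 nM (a limit)
Compound 2 `CCOc1ccc(C(O)C2OC(=O)c3c(OC)cc(OC)cc32)cc1`: > 40000 nM (a limit)

Both compounds were tested in an ADME assay on RAW264.7 cells (Mus musculus) for cytotoxicity, read by MTT assay, with a stated time of 24 h, in the absence of a further agent; a lower number here means a stronger inhibitor, a higher number a weaker inhibitor. Compound 1 reads > 40000 nM, which is a limit of the assay and not a number. Compound 2 reads > 40000 nM, which is also a limit and not a number. Among the compounds with values here, no measured step links the two, and they cannot be ranked.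

Compound 3 `CCOCCOc1ccc(C(O)C2OC(=O)c3c(OC)cc(OC)cc32)cc1` differs from compound 2 in one place: ethoxy in place of hydrogen on a saturated chain carbon, two bonds along the chain from an oxygen on an aromatic ring. Ethoxy replaces hydrogen on a saturated chain carbon, two bonds along the chain from an oxygen on an aromatic ring, so ethoxy becomes 2-ethoxyethoxy.

The expectation rests on compound 2, with its > 40000 nM. The estimated step of a number no higher from compound 2 to compound 3 (the limit leaves the size open) in this assay is none beyond the scatter, with no direction expected. For compound 3 the estimated value is 40000 nM, with an expected range of 20000 nM to 80000 nM.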

Compound 3, half-maximal inhibitory concentration: > 40000 nM
Compound 3: a limit, no number; the forecaster's own chance of this, stated with the estimate: 85%; the middle value lies on the limit itself.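

Compound 2 and compound 3 both sit at a limit and not at a number, so no step between them can be read: the limit of > 40000 nM in this assay, at which 3 of the 3 values shown sit.

The compounds shown leave open whether 2-ethoxyethoxy in place of ethoxy changes the reading in this assay at all, as none of them gives a number there.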